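The source may hold more compounds than are shown below. What is called first, only, known or untested is meant among the compounds shown, and "the series" means these compounds.

Measured so far:
- Compound 1, `O=C(CSc1nc(Nc2ccccc2)c2ccccc2n1)Nc1cccc(Br)c1`: 17500 nM
- Compound 2, `O=C(CSc1nc(Nc2ccccc2)c2ccccc2n1)Nc1ccc(C(F)(F)F)cc1`: 11100 nM

Among the compounds with values here, compound 2 stands at the lower of the two numbers so far recorded in a functional assay on MDA-MB-231 cells (Homo sapiens) for inhibition, read by MTT assay, with a stated time of 72 h (on this read-out higher numbers stand for weaker inhibition and lower numbers for stronger inhibition), but the gap to compound 1 is small: a 1.6-fold lower number from compound 1 to compound 2 (0.20 log units; within the scatter). The two compounds therefore cannot be ranked against each other on this assay.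

Compound 3, `O=C(CSc1nc(Nc2ccccc2)c2ccccc2n1)Nc1ccc(F)c(Cl)c1`, has not yet been measured. It differs from compound 2 in one place: 3-chloro-4-fluorophenyl in place of 4-(trifluoromethyl)phenyl on an amide-type nitrogen. Within the data shown here, the only measured step that bears on this change is the one from compound 1 to compound 2, in which one substituted phenyl on the amide-type nitrogen was exchanged for another, and that step stayed within the scatter. The present exchange is of the same kind, one substituted phenyl for another on the same nitrogen, so the expectation is that this assay will again show no step beyond the scatter, with the estimated step being a 1.2-fold higher number from compound 2 to compound 3 (0.07 log units; within the scatter). On that basis compound 3 is expected to give 13000 nM, within a range from 6000 nM to 28000 nM.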

Compound 3, half-maximal inhibitory concentration: 21600 nM
Beside the measured number, compound 3's estimate is 1.7-fold (0.22 log units) below it; the range from low to high includes it.
By their numbers in this assay, from the lowest: compounds 2, 1 and 3 (each within the scatter of the next).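

In this assay the third substituted phenyl on the amide-type nitrogen gives a 1.9-fold higher number from compound 2 to compound 3 (0.29 log units; within the scatter) and also a 1.2-fold higher number from compound 1 to compound 3 (0.09 log units; within the scatter). Every pair among the three compounds now lies within the scatter, so 3-bromophenyl, 4-(trifluoromethyl)phenyl and 3-chloro-4-fluorophenyl cannot be told apart at this place on this read-out, even though the exchange in compound 3 also alters the number of heavy atoms in the group and brings chlorine and fluorine together on one ring. No supporting information accompanies these numbers to explain this flat picture.

All three compounds carry a halogen-bearing phenyl on this nitrogen and share the rest of the core, so the compounds shown do not tell whether this position responds at all to a larger change. As far as these compounds go, it remains open whether an unsubstituted phenyl, a phenyl bearing an amine or a carboxylic acid, or a longer chain in place of the ring would give a step beyond the scatter in this assay.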